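The compounds below may be only part of what the source reports. "The series", "measured", "known", "first", "only" and "open" are said of these compounds alone.

Measured so far in a functional assay on DU-145 cells (Homo sapiens) for inhibition, read by trypan blue exclusion, with a stated time of 96 h; a higher number here means a weaker inhibitor of growth, a lower number a stronger inhibitor of growth:
Compound 1 `O=C(/C(=C\c1c(O)cc(O)cc1O)SCc1ccc(Cl)cc1)c1ccc(Cl)cc1`: > 100000 nM, a limit
Compound 2 `O=C(/C(=C\c1c(O)cc(O)cc1O)S(=O)(=O)c1ccc(Br)cc1)c1ccc(Cl)cc1`: > 100000 nM, a limit
Compound 3 `Cc1ccc(S(=O)(=O)/C(=C/c2ccccc2F)C(=O)c2ccc(Cl)cc2)cc1`: 2500 nM

For the measured compounds named here, compound 3, at 2500 nM, holds the only true number here. The other two results are the limit of > 100000 nM in this assay, at which 2 of the 3 values shown sit.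

Compound 4 `Cc1ccc(S(=O)(=O)/C(=C/c2c(O)cc(O)cc2O)C(=O)c2ccc(Cl)cc2)cc1` differs from compound 3 in one place: 2,4,6-trihydroxyphenyl in place of 2-fluorophenyl on a double-bonded chain carbon bound to a double-bonded chain carbon.

Going by the values given here, the one measured step, a step that the two limits leave unreadable from compound 1 to compound 2, offers no size to carry over. The closest guide is the group that enters. Compound 1 carries 2,4,6-trihydroxyphenyl and stands at > 100000 nM, a limit. Compound 2 carries it too and stands at > 100000 nM, also a limit. Among the compounds with values here, these are only two compounds, and both differ from compound 4 elsewhere as well, so the guide is thin. Even so, a large step to a higher number, meaning weaker growth inhibition, is expected in this assay.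

The expected step is a 28-fold higher number from compound 3 to compound 4 (1.45 log units; beyond the scatter).

Compound 4 is estimated at 70000 nM, with an expected range of 15000 nM to 150000 nM, and a result reported only as a limit would be no surprise.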

Compound 4, concentration for 50% growth inhibition: > 100000 nM
Compound 4 was reported as a limit (the forecaster's own chance of this, stated with the estimate: 65%); middle value at least 1.4-fold (0.15 log units) from the limit.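

In this assay, for the compounds shown here, putting 2,4,6-trihydroxyphenyl in place of 2-fluorophenyl on a double-bonded chain carbon bound to a double-bonded chain carbon gives an at least 40-fold higher number from compound 3 to compound 4 (1.60 log units; beyond the scatter), the first step at this position whose size can be read, at least in part. Compound 1 and compound 2 also carry 2,4,6-trihydroxyphenyl, but neither has a partner differing only at this position, so the loss of growth inhibition can be tied to this single change only now. The steps among compound 1, compound 2 and compound 4 cannot be read, and all three share one ceiling: the limit of > 100000 nM in this assay, at which 3 of the 4 values shown sit.

On these data alone, the result for compound 4 is a limit, so the full size of the step stays open. Also open, as far as these compounds go, is whether an aminophenyl or a methoxyphenyl group at this position would keep growth inhibition closer to that of compound 3.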